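The source may hold more compounds than are shown below. What is called first, only, known or untested is meant among the compounds shown, and "the series" means these compounds.

Compound 1 `O=S(=O)(c1cccc(-c2ccc3nccc(-c4ccncc4)c3n2)c1)N1CCC(O)CC1`: 11%
Compound 2 `CS(=O)(=O)Nc1cccc(-c2ccc3nccc(-c4ccncc4)c3n2)c1`: 49%

In an ADME assay on microsomes from liver (Rattus norvegicus) for metabolic stability, read by LC-MS, using NADPH, with a stated time of 30 min, tested at 0.1 uM (on this read-out higher numbers stand for a more stable compound and lower numbers for a less stable compound), compound 2 stands highest of the two measured compounds at 49%. Compound 3 `O=S(=O)(c1cccc(-c2ccc3nccc(-c4ccncc4)c3n2)c1)N1CC[C@H](O)C1` differs from it as follows: (3-hydroxypyrrolidin-1-yl)sulfonyl in place of methanesulfonamido on an aromatic carbon. For the measured compounds named here, one measured step bears on this change: a number 38 percentage points higher from compound 1 to compound 2 (beyond the scatter), a large one, in which methanesulfonamido replaced (4-hydroxypiperidin-1-yl)sulfonyl. The new change runs the opposite way, from methanesulfonamido to (3-hydroxypyrrolidin-1-yl)sulfonyl, so a large fall is expected in this assay. The estimated step is a number 33 percentage points lower from compound 2 to compound 3 (beyond the scatter). The expected value for compound 3 is 16%, within an estimated range of 5% to 33%.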

Compound 3, percent of the compound remaining: 10%
Compound 3: the middle estimate sits 6 percentage points above what was measured, within the range that was stated.
By their numbers in this assay, from the lowest: compounds 3 and 1 (each within the scatter of the next); then compound 2.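

In this assay the new result is a number 39 percentage points lower from compound 2 to compound 3 (beyond the scatter), so the large gap to methanesulfonamido on this aromatic carbon is not particular to the 4-hydroxypiperidin-1-yl group. Between the two sulfonyl compounds the step is a number 1 percentage points lower from compound 1 to compound 3 (within the scatter), and these two amines on the sulfonyl sulfur cannot be told apart here. Nothing available explains the gap between the sulfonyl compounds and compound 2. Still open, going by these compounds, is whether the low numbers go with the ring or with its hydroxyl, and where a plain piperidin-1-yl or a dimethylamino group on the sulfonyl sulfur would stand.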